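Ester chain variation from compound 1 toward compound 3

A few compounds are considered here, and "the series" means these few. Any claim that something is new, unique, unknown or untested is made for them only; others in the source may bear on it.

Measured so far in an ADME assay on RAW264.7 cells (Mus musculus) for cytotoxicity, read by MTT assay, with a stated time of 24 h; a lower number here means that less compound is tolerated, a higher number that more compound is tolerated:
compound 1 `CC/C=C\C[C@H]1C(=O)C=C[C@H]1CC(=O)OCCC` gives 35 uM
compound 2 `CC/C=C\C[C@H]1C(=O)C=C[C@H]1CC(=O)OC(C)CC` gives 53 uM

Compound 1 stands lowest of the two numbers; its nearest neighbour is compound 2, a 1.5-fold higher number from compound 1 to compound 2 (0.18 log units; within the scatter). Compound 3 `CC/C=C\C[C@H]1C(=O)C=C[C@H]1CC(=O)OC(C)COC` is not yet measured. It differs from compound 1 by 1-(methoxymethyl)ethyl in place of propyl on an oxygen next to a carbonyl group. The step from compound 1 to compound 2 is the only one that bears on this change; it touched the same chain carbon and stayed within the scatter. Among the measured compounds shown here, no measured step covers the methoxymethyl part. The expected step is therefore small, a 1.2-fold higher number from compound 1 to compound 3 (0.08 log units; within the scatter), within the scatter. Compound 3 is expected to give 42 uM, in the range 20 uM to 90 uM.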

Compound 3, half-maximal toxic concentration: 161 uM
The estimate for compound 3 lay 3.8-fold (0.58 log units) below the measured number, outside the stated range (above it).
By their numbers in this assay, from the lowest: compounds 1 and 2 (each within the scatter of the next); then compound 3.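

In this assay, 1-(methoxymethyl)ethyl in place of propyl on an oxygen next to a carbonyl group gives a 4.6-fold higher number from compound 1 to compound 3 (0.66 log units; beyond the scatter), so this position does respond to change. The larger move goes with the methoxy: methoxy in place of methyl gives a 3.0-fold higher number from compound 2 to compound 3 (0.48 log units; beyond the scatter), while methyl in place of hydrogen gave a 1.5-fold higher number from compound 1 to compound 2 (0.18 log units; within the scatter). No supporting measurement accounts for this shift. Among the compounds shown here, compound 3 is the only compound carrying an ether oxygen in the chain, so the shift rests on a single example. From the compounds shown here alone, whether a hydroxyl or an amine in place of the methoxy would behave alike remains open.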